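A few compounds are considered here, and "the series" means these few. Any claim that something is new, unique, unknown or untested is made for them only; others in the source may bear on it.

Working notes on the series, read in a functional assay on VCaP cells (Homo sapiens) for antiproliferative activity, read by CCK-8 assay, with a stated time of 6 days; a lower number here means a stronger inhibitor, a higher number a weaker inhibitor. Compound 1 (`CC(=O)c1ccc(S(=O)(=O)N[C@@H](C)Cn2ccc(-c3ccc(C#N)c(Cl)c3)n2)cc1`) gives 3950 nM and compound 2 (`C[C@@H](Cn1ccc(-c2ccc(C#N)c(Cl)c2)n1)NS(=O)(=O)c1cccnc1`) gives 2450 nM, two numbers within the scatter of each other. Compound 3 (`C[C@@H](Cn1ccc(-c2cc(F)c(C#N)c(Cl)c2)n1)NC(=O)Nc1cc(C(C)(C)C)[nH]n1`) gives 5120 nM, which is beyond the scatter from the number of compound 2. Compound 2 therefore stands at the low end of this small set, level with compound 1 within the scatter.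

The next structure is compound 4 (`C[C@@H](Cn1ccc(-c2ccc(C#N)c(Cl)c2)n1)Nc1ccncc1`), with pyridin-4-yl in place of (pyridin-3-yl)sulfonyl on an amine nitrogen.

For the measured compounds named here, only one measured step is available, a 1.6-fold lower number from compound 1 to compound 2 (0.21 log units; within the scatter). It exchanges the group on a sulfonyl sulfur and keeps the sulfonyl itself, and it stays within the scatter. Going by the values given here, it bears only loosely on this change, since no measured step removes a sulfonyl. Among the compounds with values here, compound 3 differs from compound 2 in more than one place and offers no clean step. The data therefore give no direction, and no step beyond the scatter is expected in this assay, though with wide uncertainty. The estimate amounts to an expected 1.2-fold higher number from compound 2 to compound 4 (0.09 log units; within the scatter). For compound 4 the estimated value is 3000 nM, with an expected range from 800 nM to 10000 nM.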

Compound 4, half-maximal inhibitory concentration: 9900 nM
Compound 4: middle estimate off by 3.3-fold (0.52 log units), on the low side, within the range that was stated.
By their numbers in this assay, from the lowest: compounds 2, 1, 3 and 4 (each within the scatter of the next, the first and the last beyond it).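

In this assay, for the compounds shown here, this is the first step that removes the sulfonyl from the amine nitrogen, and it gives a 4.0-fold higher number from compound 2 to compound 4 (0.61 log units; beyond the scatter). Going by these compounds alone, the only earlier clean step, a 1.6-fold lower number from compound 1 to compound 2 (0.21 log units; within the scatter), exchanged the group on the sulfonyl sulfur while keeping the sulfonyl, so the new result shows that this position can respond beyond the scatter when the group attached to the amine nitrogen is replaced as a whole. The change replaces (pyridin-3-yl)sulfonyl, with its 9 heavy atoms and 3 hydrogen-bond acceptors, by pyridin-4-yl, with 6 heavy atoms and 1 hydrogen-bond acceptor, and no available evidence accounts for the higher number of compound 4.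

The step combines loss of the sulfonyl with a change in the pyridine attachment named in the two groups, so the compounds shown cannot separate these two contributions. On these data alone, it remains open whether a pyridine-3-carbonyl group on the same amine nitrogen would give a number closer to that of compound 2 or to that of compound 4.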